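The source may report more compounds than this note shows. Statements on the series, on what has been measured and on what is new or still open speak of the compounds shown alone.

Of the compounds shown here, three built on a shared core have been tested in a functional assay on CHO cells for agonist activity at prostaglandin E2 receptor EP2 subtype (Homo sapiens), read by HTRF and cAMP accumulation, with a stated time of 30 min; a lower number here means that less compound is needed, a higher number that more compound is needed for the effect. Within the data shown here, compound 1 `O=C(O)c1csc([C@H]2CC[C@@H]3[C@@H](/C=C/COc4ccccc4)[C@H](O)C[C@@H]3O2)n1` gives 3.8 nM, and compound 3 `O=C(O)c1csc([C@H]2CC[C@@H]3[C@@H](/C=C/CCOc4ccccc4)[C@H](O)C[C@@H]3O2)n1` gives 3.9 nM; the single change between them, a 1.0-fold higher number from compound 1 to compound 3 (0.01 log units; within the scatter), stays within the scatter, so the longer chain ending in phenoxy made no visible difference. Compound 2 `Cc1ccc(OC[C@@H]2[C@H]3CC[C@H](c4nc(C(=O)O)cs4)O[C@H]3C[C@H]2O)cc1` gives 27 nM, the highest of the three numbers, and its distance from compound 3 as well as from compound 1 lies beyond the scatter. Compound 4 `O=C(O)c1csc([C@H]2CC[C@@H]3[C@@H](CCCOc4ccccc4)[C@H](O)C[C@@H]3O2)n1` is not yet measured. It differs from compound 2 in one place: 2-phenoxyethyl in place of 4-methylphenoxy on a saturated chain carbon bound to a saturated ring carbon. Among the measured compounds shown here, no measured pair shows exactly this change, and no measured pair removes a double bond from the chain. Because compound 1 gives 3.8 nM and compound 3 gives 3.9 nM with chains that also end in phenoxy, a number below that of compound 2 seems likely. The step expected from this change is a 3.4-fold lower number from compound 2 to compound 4 (0.53 log units; beyond the scatter). Compound 4 is estimated at 8 nM, with a range from 3 nM to 25 nM.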

Compound 4, half-maximal effective concentration: 10 nM
Compound 4: the middle estimate sits 1.3-fold (0.10 log units) below what was measured, within the range that was stated.
By their numbers in this assay, from the lowest: compounds 1 and 3 (each within the scatter of the next); then compound 4; then compound 2.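

Moving from the ring-bearing 4-methylphenoxy to the 2-phenoxyethyl end group on this saturated chain carbon gives a modest but real change, a 2.7-fold lower number from compound 2 to compound 4 (0.43 log units; beyond the scatter), so this position does respond to what is attached to it. The earlier chain change, a 1.0-fold higher number from compound 1 to compound 3 (0.01 log units; within the scatter), stayed within the scatter on a chain holding a double bond, and so gave no such sign. Nothing available explains why the number falls here.

This single step swaps two things at once, losing the methyl on the ring and lengthening the chain, and a plain phenoxy at this place would be needed to tell them apart. Among these compounds, how far a fully saturated chain differs from one with a double bond also stays open, with compound 1 at 3.8 nM and compound 4 at 10 nM as the only printed values.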